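The source may hold more compounds than are shown below. What is called first, only, known or untested is meant among the compounds shown, and "the series" means these compounds.

Measured so far in an ADME assay on HepG2 2.2.15 cells (Homo sapiens) for cytotoxicity; a lower number here means that less compound is tolerated, a higher number that more compound is tolerated:
- compound 1 `O=c1[nH]c2ccc(Cl)cc2c(-c2ccccc2Cl)c1CCO`: 380000 nM
- compound 2 `C=CCn1c(=O)c(CCO)c(-c2ccccc2Cl)c2cc(Cl)ccc21`: 23000 nM
- compound 3 `O=c1c(CCO)c(-c2ccccc2Cl)c2cc(Cl)ccc2n1-c1ccccc1`: 26000 nM

Compound 2 stands at 23000 nM, well away from compound 1, with a 17-fold lower number from compound 1 to compound 2 (1.22 log units; beyond the scatter). It cannot be separated from compound 3, with a 1.1-fold higher number from compound 2 to compound 3 (0.05 log units; within the scatter).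

The next compound, compound 4 `O=c1c(CCO)c(-c2ccccc2Cl)c2cc(Cl)ccc2n1-c1c(F)cccc1F`, has 2,6-difluorophenyl in place of allyl on an aromatic nitrogen.

The closest measured precedent is the step from allyl to phenyl at that nitrogen, which stayed within the scatter in a 1.1-fold higher number from compound 2 to compound 3 (0.05 log units; within the scatter). The large steps, a 17-fold lower number from compound 1 to compound 2 (1.22 log units; beyond the scatter) and a 15-fold lower number from compound 1 to compound 3 (1.16 log units; beyond the scatter), both replace hydrogen on that nitrogen, and compound 2 already carries a substituent there. Going by the values given here, no compound with fluorine on the phenyl group has been measured, so that part of the change remains untested. No step beyond the scatter is therefore expected in this assay.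

The expected step is a 1.0-fold lower number from compound 2 to compound 4 (0.02 log units; within the scatter).

For compound 4 the estimated value is 22000 nM, with an expected range of 9000 nM to 55000 nM.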

Compound 4, half-maximal cytotoxic concentration: > 2300000 nM
Compound 4: only a limit was reported; the forecaster's own chance of this, stated with the estimate: 5%; at least 100-fold (2.01 log units) between middle value and limit.
By their numbers in this assay, from the lowest: compounds 2 and 3 (each within the scatter of the next); then compound 1. At a limit, above all of these: compound 4.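

In this assay the group on this nitrogen now matters: the change gives an at least 100-fold higher number from compound 2 to compound 4 (2.00 log units; beyond the scatter) and an at least 88-fold higher number from compound 3 to compound 4 (1.94 log units; beyond the scatter), so 2,6-difluorophenyl separates clearly from both allyl and phenyl, which themselves stayed within the scatter of each other. Substitution on this nitrogen is also not tied to a lower number, since 2,6-difluorophenyl in place of hydrogen gives an at least 6.0-fold higher number from compound 1 to compound 4 (0.78 log units; beyond the scatter), the opposite direction to allyl and phenyl. Compound 4 is reported only as a limit, so these steps have a lower bound and no true size: the limit of > 2300000 nM in this assay, at which 1 of the 4 values shown sits.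

Open, on these data alone, is whether a single fluorine on the phenyl group already gives this shift, or whether 2,6-difluorophenyl is needed. Also open, as far as these compounds go, is how a benzyl group or a longer chain ending in an amine would behave on this nitrogen.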